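This account rests on a few compounds, and the source may have more. Where it says the series, first, only, none or still open, it means among the compounds named here.

The series rests on three measured compounds. Compound 1 `Cc1ccc2nc(/N=C3\C(=O)N(CN(C)C)c4cccc(Cl)c43)sc2c1` gives 28100 nM in a functional assay on MDA-MB-468 cells (Homo sapiens) for cytotoxicity, read by sulforhodamine B assay, with a stated time of 48 h; on this read-out higher numbers stand for weaker inhibition of growth and lower numbers for stronger inhibition of growth. Compound 2 `Cc1ccc2nc(/N=C3\C(=O)N(CN4CCCCC4)c4cccc(Cl)c43)sc2c1` gives 19800 nM in the same assay, and a 1.4-fold lower number from compound 1 to compound 2 (0.15 log units; within the scatter). Compound 3 `CCN(CC)CN1C(=O)/C(=N\c2nc3ccc(C)cc3s2)c2ccccc21` gives 63500 nM, the highest of the three numbers; its gap to compound 1 and its gap to compound 2 both lie beyond the scatter, so compound 3 inhibits growth least strongly of the measured set.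

Compound 4 `CCN(CC)CN1C(=O)/C(=N\c2nc3ccc(C)cc3s2)c2c(Cl)cccc21` is to be measured. It differs from compound 3 by a single change: chloro in place of hydrogen on an aromatic carbon. Among the measured compounds shown here, no measured pair differs in exactly this way, so no step speaks to it directly. For the measured compounds named here, compound 3 and compound 1 differ in two places, the amine on the chain carbon and the chloro, and the only measured step, from compound 1 to compound 2, shows that swapping the amine stays within the scatter. Taken together, the two values of compound 3 and compound 1 leave the chloro as the open variable, and compound 4 is therefore expected to move toward compound 1, with a 2.1-fold lower number from compound 3 to compound 4 (0.33 log units; beyond the scatter) as the estimated step. The expected value for compound 4 is 30000 nM, in a range from 15000 nM to 60000 nM.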

Compound 4, concentration for 50% growth inhibition: 27300 nM
For compound 4 the middle estimate is 1.1-fold (0.04 log units) above the measured one; the measured number falls inside the stated range.
By their numbers in this assay, from the lowest: compounds 2, 4 and 1 (each within the scatter of the next); then compound 3.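

Among the compounds shown here, in (this assay) the chloro in place of hydrogen on this aromatic carbon, ortho to a fused ring, now has a step of its own (a 2.3-fold lower number from compound 3 to compound 4 (0.37 log units; beyond the scatter)), a modest move, whereas the earlier compounds carried this change only together with a change of amine. With the chloro in place, diethylamino joins dimethylamino and piperidin-1-yl on the chain carbon, with all three steps inside the scatter (a 1.0-fold lower number from compound 1 to compound 4 (0.01 log units; within the scatter); a 1.4-fold higher number from compound 2 to compound 4 (0.14 log units; within the scatter); a 1.4-fold lower number from compound 1 to compound 2 (0.15 log units; within the scatter)), so among these three amines in the chloro compounds, the choice of amine leaves the read-out within the scatter. No measurement on hand accounts for the chloro step.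

For the compounds shown here, the chloro step rests on the single pair with diethylamino, so its size with dimethylamino or piperidin-1-yl on the chain carbon remains open, as does whether fluoro, bromo or methoxy at this same aromatic carbon would move the number as chloro does. Also open, on these data alone, is whether a morpholine on the chain carbon, or a hydrogen on the amide-type nitrogen in place of the whole aminomethyl chain, would stay within the scatter of the chloro compounds.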